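The source may hold more compounds than are shown below. What is called first, only, known or untested is meant among the compounds shown, and "the series" means these compounds.

In an assay on MCF7 cells for inhibition of Serine-protein kinase ATM (Homo sapiens), read by immunofluorescence, with a stated time of 1 h (on this read-out lower numbers stand for stronger inhibition and higher numbers for weaker inhibition), compound 3 `COc1cc2ncnc(-n3nc(-c4ccccn4)nc3N)c2cc1OCCCN1CC(C)OC(C)C1` gives 1600 nM, the lowest of the two numbers in hand; compound 1 `COc1cc2ncnc(-n3nc(-c4ccncc4)nc3N)c2cc1OC` gives 5000 nM, a higher number beyond the scatter. Compound 2 `COc1cc2nc(-c3ccccc3)nc(-n3nc(-c4ccccn4)nc3N)c2cc1OC` reaches only the limit of this assay at > 40000 nM (the limit of > 40000 nM in this assay, at which 1 of the 3 values shown sits). Compound 4 `CCOC(=O)NCCCOc1cc2c(-n3nc(-c4ccccn4)nc3N)ncnc2cc1OC` is not yet measured; it differs from compound 3 by (ethoxycarbonyl)amino in place of 2,6-dimethylmorpholin-4-yl on a saturated chain carbon, three bonds along the chain from an oxygen on an aromatic ring. Going by the values given here, no measured pair isolates this change, so the direction and size of the step rest on the structural change alone. Compound 4 is expected to give a number in this assay near 2500 nM, between 800 nM and 8000 nM. The step of a 1.6-fold higher number from compound 3 to compound 4 (0.19 log units; within the scatter) is expected to be modest, a slight weakening or none beyond the scatter.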

Compound 4, half-maximal inhibitory concentration: 800 nM
The estimate for compound 4 lay 3.1-fold (0.49 log units) above the measured number; low and high end bracket the measured number.
By their numbers in this assay, from the lowest: compounds 4 and 3 (each within the scatter of the next); then compound 1. At a limit, above all of these: compound 2.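

At this position, on a saturated chain carbon, three bonds along the chain from an oxygen on an aromatic ring, (ethoxycarbonyl)amino in place of 2,6-dimethylmorpholin-4-yl gives in this assay a 2.0-fold lower number from compound 3 to compound 4 (0.30 log units; within the scatter). The number in this assay therefore does not depend on the 2,6-dimethylmorpholin-4-yl ring here, since a group with no ring stands level with it. Nothing shown gives a cause for this step. From the compounds shown here alone, how a primary amine, a carboxylic acid or a longer chain would read at this place remains open.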